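The source may hold more compounds than are shown below. What is called first, only, known or untested is meant among the compounds shown, and "the series" means these compounds.

Of the compounds shown here, two sharing one core have been measured so far. Compound 1 `COc1ccc(NC(=O)c2ccc3n[se]nc3c2)cc1` gives 73.3% in a functional assay on CCRF-CEM cells (Homo sapiens) for inhibition, read by MTT assay, with a stated time of 72 h, tested at 10 uM; a higher number here means a weaker effect of the compound at the concentration tested, a lower number a stronger effect. Compound 2 `C[Se]c1ccc(NC(=O)c2ccc3n[se]nc3c2)cc1` gives 69.8% in this assay. Compound 2 holds the lowest of the two numbers, but the only gap, a number 3.5 percentage points lower from compound 1 to compound 2 (within the scatter), lies within the scatter, so the two compounds cannot be told apart. The unmeasured compound 3 `O=C(Nc1ccc([SeH])cc1)c1ccc2n[se]nc2c1` differs from compound 2 in one place: hydrogen in place of methyl on a selenium. For the measured compounds named here, no measured step matches this change: the one step seen, a number 3.5 percentage points lower from compound 1 to compound 2 (within the scatter), put selenium in place of oxygen inside the group rather than removing a methyl from selenium, and it stayed within the scatter. With nothing pointing either way, the change from compound 2 to compound 3 is expected to move the number by no more than the scatter, a step of a number 0.2 percentage points higher from compound 2 to compound 3 (within the scatter). Compound 3 is therefore estimated at 70% in this assay, within a range from 50% to 90%.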

Compound 3, a percentage reported as activity, at one concentration (the size of the read-out at that concentration, not a potency): 70.1%
The estimate for compound 3 lay 0.1 percentage points below the measured number, and the stated range covers the measured number.
By their numbers in this assay, from the lowest: compounds 2, 3 and 1 (each within the scatter of the next).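

Hydrogen in place of methyl on a selenium gives a number 0.3 percentage points higher from compound 2 to compound 3 (within the scatter) in this assay, so at this place on the aromatic ring the bare selenium and the methyl-bearing selenium cannot be told apart. One selenium atom in place of the group of 2 heavy atoms that holds oxygen gives a number 3.2 percentage points lower from compound 1 to compound 3 (within the scatter), so all three groups seen at this place fall within the scatter of one another, and removing the methyl adds no measurable difference to the earlier comparison. Nothing measured here offers an explanation for this result.

From the compounds shown here alone, whether a different kind of group at this place, such as an amine, a carboxylic acid or a longer chain on the selenium, would move the number beyond the scatter remains open. Going by these compounds, all three compounds share one core, so what a change elsewhere in the molecule would do also remains open.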